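The compounds below may be only part of what the source reports. "The series", "measured", "known", "first", "only" and "open" are said of these compounds alone.

In a toxicity assay on MT4 cells (Homo sapiens) for cytotoxicity, read by MTT assay (a higher number here means that more compound is tolerated, a lower number that less compound is tolerated), compound 2 (`Cc1cc(-c2ccc(Cl)cc2)cc(C)c1Oc1cc(N)nc(Nc2ccc(C#N)cc2)n1`) gives 21500 nM, and compound 1 (`Cc1cc(-c2ccccc2F)cc(C)c1Oc1cc(N)nc(Nc2ccc(C#N)cc2)n1`) gives 29300 nM. Going by the values given here, these are the only two numbers so far and they lie within the scatter of each other, so compound 2 holds no distinct place on this scale. The two compounds share a core and differ in one group, with 4-chlorophenyl in place of 2-fluorophenyl, and the measured result is a 1.4-fold lower number from compound 1 to compound 2 (0.13 log units; within the scatter).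

Compound 3 (`Cc1ccccc1-c1cc(C)c(Oc2cc(N)nc(Nc3ccc(C#N)cc3)n2)c(C)c1`) changes that same place again, with 2-methylphenyl in place of 4-chlorophenyl on an aromatic carbon. Among the compounds with values here, the one measured step bears directly on this change, as it too exchanges one substituted phenyl group for another on that carbon. Within the data shown here, it is thin evidence, and no compound with a 2-methylphenyl group has yet been measured. Even so, no step beyond the scatter is expected in this assay, and no clear direction can be argued. The expected result is a 1.2-fold higher number from compound 2 to compound 3 (0.07 log units; within the scatter). For compound 3 the estimated value is 25000 nM, with an expected range from 12000 nM to 50000 nM.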

Compound 3, half-maximal cytotoxic concentration: 25600 nM
For compound 3 the middle estimate is 1.0-fold (0.01 log units) below the measured one, within the range that was stated.
By their numbers in this assay, from the lowest: compounds 2, 3 and 1 (each within the scatter of the next).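

In this assay, the exchange of 4-chlorophenyl for 2-methylphenyl gives a 1.2-fold higher number from compound 2 to compound 3 (0.08 log units; within the scatter), so a third substituted phenyl group on this aromatic carbon, para to a large group and meta to two methyl groups, stays within the scatter of the second. The new compound also provides a narrower comparison than the earlier pair, because methyl in place of fluoro on the phenyl group gives a 1.1-fold lower number from compound 1 to compound 3 (0.06 log units; within the scatter), and this assay does not separate the 2-fluorophenyl and 2-methylphenyl compounds. No accompanying measurement bears on why these three compounds lie so close, and the numbers themselves offer no explanation.

From the compounds shown here alone, all three compounds carry a phenyl group with one substituent at this place, so it remains open whether an amine, a carboxylic acid or a longer chain on the same carbon would give a step beyond the scatter. Going by these compounds alone, the compounds also leave open how a single substituent would read when moved around the phenyl group, since the 4-chlorophenyl compound has no 2-chlorophenyl counterpart among them, and how changes elsewhere on the shared core would read in this assay.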